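The source may report more compounds than this note shows. Statements on the series, on what has been measured and on what is new or still open speak of the compounds shown alone.

The study sets three measured compounds beside one still to be measured, all built on a shared core. Compound 1 `CCOC(=O)C1=C(C)NC(=S)NC1c1ccc(O)c(O)c1` gives 31.7 ug/mL in a functional assay on NCI-H460 cells (Homo sapiens) for inhibition, read by sulforhodamine B assay, with a stated time of 48 h (on this read-out higher numbers stand for weaker inhibition of growth and lower numbers for stronger inhibition of growth), while compound 2 `CCOC(=O)C1=C(C)NC(=O)NC1c1ccc(O)c(O)c1` gives 34 ug/mL in this assay. Compound 3 `CCOC(=O)C1=C(C)NC(=S)NC1c1ccc(OC)cc1` gives 31.4 ug/mL in this assay; this is the lowest of the three numbers, yet its gaps to compound 1 and to compound 2 both lie within the scatter of the measurement, so the three values cannot be told apart. Compound 4 `CCOC(=O)C1=C(C)NC(=S)NC1c1ccc(O)cc1` differs from compound 3 in a single place: hydrogen in place of methyl on an oxygen on an aromatic ring. Within the data shown here, no pair of measured compounds isolates this change, so the expectation rests on how closely the three known values sit together despite their differing substituents. Compound 4 is therefore expected to stay close to compound 3, with a step of a 1.0-fold higher number from compound 3 to compound 4 (0.01 log units; within the scatter) that is not expected to reach beyond the scatter in either direction. The estimate for compound 4 in this assay is 32 ug/mL, with a range from 16 ug/mL to 64 ug/mL.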

Compound 4, concentration for 50% growth inhibition: > 250 ug/mL
Compound 4 was reported as a limit (the forecaster's own chance of this, stated with the estimate: 5%); middle value at least 7.8-fold (0.89 log units) away from the limit.
By their numbers in this assay, from the lowest: compounds 3, 1 and 2 (each within the scatter of the next). At a limit, above all of these: compound 4.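

In this assay, the value of compound 4 is a limit of the assay and not a number: the limit of > 250 ug/mL in this assay, at which 1 of the 4 values shown sits. Until now, the values gave no sign that the substituents on this aromatic ring mattered, but hydrogen in place of methyl on this oxygen gives an at least 7.9-fold higher number from compound 3 to compound 4 (0.90 log units; beyond the scatter), so the change from methoxy to hydroxy at this place is not neutral. Hydrogen in place of hydroxy on an aromatic carbon gives an at least 7.8-fold higher number from compound 1 to compound 4 (0.89 log units; beyond the scatter), so a single added hydroxy separates the two compounds just as clearly, and a free hydroxy alone does not decide the outcome.

The compounds shown leave open whether a longer chain such as ethoxy would behave like methoxy at this place, or whether an amine would behave like hydroxy. They also leave open whether a carbonyl in place of the thiocarbonyl would change the outcome for compound 4.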